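Amide Ring Swap Expected to Leave Inhibition Unchanged

This account rests on a few compounds, and the source may have more. Where it says the series, first, only, none or still open, it means among the compounds named here.

Compound 3 `C[C@@H]1N[C@H](C(=O)N2CCC[C@H]2C#N)C[C@@H]1C(=O)N1CCOCC1` stands level with compound 1 `C[C@@H]1N[C@H](C(=O)N2CCC[C@H]2C#N)C[C@@H]1C(=O)N1CCC1` in an assay on the whole organism (plasma, strain Sprague-Dawley) for inhibition of Dipeptidyl peptidase 4 (Rattus norvegicus), with a stated time of 6 h, at a dose of 1 mg/kg by the oral route; on this read-out lower numbers stand for less inhibition and higher numbers for more inhibition at the one dose given (going by the name of the read-out): compound 3 gives 94%, compound 1 gives 94%, and the step is no change at the digits printed from compound 1 to compound 3 (within the scatter). Compound 2 `CCN(C)C(=O)[C@H]1C[C@@H](C(=O)N2CCC[C@H]2C#N)N[C@H]1C` gives 92%, with a step of a number 2 percentage points higher from compound 2 to compound 3 (within the scatter), so all three sit together at the top of the set. The unmeasured compound 4 `C[C@@H]1N[C@H](C(=O)N2CCC[C@H]2C#N)C[C@@H]1C(=O)N1CCCC1` differs from compound 3 by pyrrolidin-1-yl in place of morpholin-4-yl on a carbonyl carbon. The two earlier exchanges of the group on the carbonyl carbon, a number 2 percentage points lower from compound 1 to compound 2 (within the scatter) and no change at the digits printed from compound 1 to compound 3 (within the scatter), both stayed within the scatter, so a further exchange there is expected to move this assay by nothing beyond the scatter. Compound 4 is therefore estimated at 93%, between 86% and 97%. This amounts to an expected step of a number 1 percentage points lower from compound 3 to compound 4 (within the scatter).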

Compound 4, a percentage reported as inhibition, in the whole organism at one dose (the size of the read-out at that dose, not a potency): 94%
The estimate for compound 4 lay 1 percentage points below the measured number; the measured number falls inside the stated range.
By their numbers in this assay, from the lowest: compounds 2, 1, 3 and 4 (each within the scatter of the next).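

In this assay, pyrrolidin-1-yl on the carbonyl carbon fits the pattern of the other groups there, with no change at the digits printed from compound 3 to compound 4 (within the scatter), no change at the digits printed from compound 1 to compound 4 (within the scatter) and a number 2 percentage points higher from compound 2 to compound 4 (within the scatter). The new point is that the ring oxygen of morpholin-4-yl is not required to hold this read-out, and a five-membered ring serves as well as the six-membered one. Nothing available explains this result. All four groups shown join the carbonyl carbon through a ring or chain nitrogen with no hydrogen on it. From the compounds shown here alone, whether a carboxylic acid or a primary amide at this place would hold the read-out stays open.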